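The source may hold more compounds than are shown below. What is called first, only, known or untested is meant among the compounds shown, and "the series" means these compounds.

Of the compounds shown here, two have been measured. Compound 1 `CCCN(CC[C@H]1CC[C@H](NC(=O)/C=C/c2cccc(F)c2)CC1)[C@H]1CCc2nc(N)sc2C1` gives 9.9 nM in an assay on brain for displacement of a labelled ligand from D(3) dopamine receptor (Rattus norvegicus); a higher number here means a weaker inhibitor, a lower number a stronger inhibitor. Compound 2 `CCCN(CC[C@H]1CC[C@H](NS(=O)(=O)c2cccc3ccccc23)CC1)[C@H]1CCc2nc(N)sc2C1` gives 1.5 nM in this assay and stands as the lower of the two numbers; the nearest is compound 1, whose higher value lies beyond the scatter of the method. Compound 3 `CCCN(CC[C@H]1CC[C@H](NS(=O)(=O)c2ccccc2)CC1)[C@H]1CCc2nc(N)sc2C1` is not yet measured. It differs from compound 2 in a single place: phenyl in place of naphthalen-1-yl on a sulfonyl sulfur. Within the data shown here, no pair of measured compounds covers this change, so the size of the step has no direct precedent. The expectation for the step from compound 2 to compound 3 is a 3.3-fold higher number from compound 2 to compound 3 (0.52 log units; beyond the scatter), a moderate move towards weaker binding that may just exceed the scatter. For compound 3 the value expected in this assay is 5 nM, with a range from 1.5 nM to 20 nM.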

Compound 3, inhibition constant: 0.79 nM
Compound 3: middle estimate off by 6.3-fold (0.80 log units), on the high side, and the stated range ends above it.
By their numbers in this assay, from the lowest: compounds 3 and 2 (each within the scatter of the next); then compound 1.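

In this assay, the sulfonyl sulfur takes phenyl as well as naphthalen-1-yl, with one six-membered aromatic ring or two and no separation beyond the scatter (a 1.9-fold lower number from compound 2 to compound 3 (0.28 log units; within the scatter)). The larger difference appears on the amine nitrogen, where phenylsulfonyl in place of (2-(3-fluorophenyl)ethenyl)carbonyl gives a step beyond the scatter (a 13-fold lower number from compound 1 to compound 3 (1.10 log units; beyond the scatter)). No supporting data are available to account for either step.

Still open, from the compounds shown here alone, is whether the sulfonyl sulfur also accepts phenyl carrying a fluorine, a methoxy group, an amine or a carboxylic acid, or a saturated group such as cyclohexyl or a short alkyl chain. Equally open, going by these compounds, is how a plain benzoyl group on the amine nitrogen would compare with phenylsulfonyl.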